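Capping the hydroxypyrimidine: an expected loss of inhibition

The source may report more compounds than this note shows. Statements on the series, on what has been measured and on what is new or still open speak of the compounds shown alone.

Among the compounds with values here, compound 2 `CCCCCCCCN(C)C(=O)Cn1cc(Cc2cnc(O)nc2)c(=O)nc1SCc1ccc(F)cc1` stands highest of the two compounds measured so far in a functional assay on a cell-free system (plasma, Oryctolagus cuniculus) for inhibition of platelet-activating factor acetylhydrolase (Homo sapiens), tested at 100 nM (a higher number here means more inhibition at the concentration tested (going by the name of the read-out), a lower number less inhibition), where compound 2 gives 34%. Within the data shown here, its nearest neighbour is compound 1 `CCCCCCCCN(C)C(=O)Cn1cc(Cc2cnc(OCC)nc2)c(=O)nc1SCc1ccc(F)cc1`, which in this assay gives 7%; the single measured step, a number 27 percentage points higher from compound 1 to compound 2 (beyond the scatter), rises beyond the scatter when hydrogen takes the place of ethyl on an oxygen on an aromatic ring. Compound 3 `CCCCCCCCN(C)C(=O)Cn1cc(Cc2cnc(=O)n(C)c2)c(=O)nc1SCc1ccc(F)cc1` has not yet been measured. Its change from compound 2 is a group of 8 heavy atoms (5 carbon, 2 nitrogen, 1 oxygen; one six-membered aromatic ring with 2 hetero atoms) in place of a group of 7 heavy atoms (4 carbon, 2 nitrogen, 1 oxygen; one six-membered aromatic ring with 2 hetero atoms), on a saturated chain carbon bound to an aromatic carbon. Among the measured compounds shown here, the only step that bears on this is a number 27 percentage points higher from compound 1 to compound 2 (beyond the scatter), a modest gain that went with the arrival of the one hydrogen-bond donor; compound 3 goes the other way, leaving no hydrogen-bond donor, so a modest fall is expected. The estimated step is a number 22 percentage points lower from compound 2 to compound 3 (beyond the scatter). Compound 3 is therefore expected to give 12%, within 0% to 30%.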

Compound 3, a percentage reported as inhibition, at one concentration (the size of the read-out at that concentration, not a potency): 19%
Estimate against measurement, compound 3: 7 percentage points below; low and high end bracket the measured number.
By their numbers in this assay, from the lowest: compound 1; then compound 3; then compound 2.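

The place on a saturated chain carbon bound to an aromatic carbon now shows three distinct levels rather than two: in this assay, the step of a number 15 percentage points lower from compound 2 to compound 3 (beyond the scatter) is joined by a number 12 percentage points higher from compound 1 to compound 3 (beyond the scatter). The group in compound 3 has 0 hydrogen-bond donors, yet the compound still stands apart from compound 1, so the absence of a donor in this group does not by itself bring the number down to the lowest level seen. Across these three compounds, the number falls as the group grows from 7 to 8 heavy atoms on going from compound 2 to compound 3, and it is lower still with the larger group of compound 1, with no compound going against that order. No measurement given here explains these differences. The compounds shown cannot separate the size of the group from its hydrogen-bond donor. They also leave open what an amine or a carboxylic acid on this ring would give.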